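Trimming one carbon from a bis-sulfonamide's dialkylamino group

This account rests on a few compounds, and the source may have more. Where it says the series, first, only, none or still open, it means among the compounds named here.

Compound 1 `CCCN(CCC)S(=O)(=O)c1ccc(S(=O)(=O)N2CCC[C@@H](C(=O)OCC)C2)cc1` carries a dipropylamino group on one sulfonyl sulfur and an ethyl ester on the saturated ring at the other end. In a functional assay on MIA PaCa-2 cells (Homo sapiens) for inhibition, read by MTT assay, with a stated time of 3 days (on this read-out higher numbers stand for weaker inhibition and lower numbers for stronger inhibition), compound 1 gives 600 nM, the lowest of the two numbers recorded among these compounds. Compound 2 `CCN(CC)S(=O)(=O)c1ccc(S(=O)(=O)N2CCC[C@@H](C(=O)NC)C2)cc1` differs from it in more than one place, and in this assay compound 2 gives 2000 nM, a value beyond the usual scatter from that of compound 1. Compound 3 `CCOC(=O)C1CCCCN1S(=O)(=O)c1ccc(S(=O)(=O)N(CC)CC)cc1` also differs in several places; in this assay compound 3 reaches only a limit, > 3000 nM, so no number is known for it (the limit of > 3000 nM in this assay, at which 1 of the 3 values shown sits).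

Compound 4 `CCOC(=O)[C@@H]1CCCN(S(=O)(=O)c2ccc(S(=O)(=O)N(CC)C(C)C)cc2)C1` is not yet measured. It departs from compound 1 by a single exchange: ethyl(isopropyl)amino in place of dipropylamino on a sulfonyl sulfur. One carbon is removed and the chain branched, with no change in ring count, hydrogen-bond donors or acceptors, or charge.

Among the measured compounds shown here, no measured pair here differs in only that one place, so there is nothing directly to lean on. Given how small the change is, the step from compound 1 to compound 4 in this assay is expected to be modest, most likely within the scatter and if anything toward a slightly higher number, a 1.3-fold higher number from compound 1 to compound 4 (0.12 log units; within the scatter). Compound 4 is therefore estimated at 800 nM, with a likely range from 300 nM to 2500 nM.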

Compound 4, half-maximal inhibitory concentration: 1200 nM
Estimate against measurement, compound 4: 1.5-fold (0.18 log units) below, and the stated range covers the measured number.
By their numbers in this assay, from the lowest: compounds 1, 4 and 2 (each within the scatter of the next, the first and the last beyond it). At a limit, above all of these: compound 3.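

In this assay compound 1 and compound 4 form the first pair shown that differs in one place only, so the group on the sulfonyl sulfur can now be read on its own, with the ethyl ester and the rest of the core unchanged. Putting ethyl(isopropyl)amino in place of dipropylamino gives a 2.0-fold higher number from compound 1 to compound 4 (0.30 log units; within the scatter) and so the two groups cannot be told apart in this assay, which means that this exchange leaves the inhibition of these cells within what repeated measurements would show. Nothing measured among these compounds offers a reason for the size of this step.

From the compounds shown here alone, it remains open whether a longer chain such as dibutylamino, or a shorter one such as dimethylamino, on that sulfonyl sulfur would move the number beyond the scatter. The other end is also unsettled, since compound 2 differs from compound 1 in more than one place and so cannot speak for its methyl amide alone, and a carboxylic acid in place of the ethyl ester is a further open question.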